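A Sulfonyl Aminophenyl Swap Against Weak Trypsin Inhibition

The source may report more compounds than this note shows. Statements on the series, on what has been measured and on what is new or still open speak of the compounds shown alone.

Compound 3 `CCOc1cc(C(Nc2ccc3c(N)nccc3c2)C(=O)NS(=O)(=O)c2cccc(N)c2)ccc1OC(C)C` is the starting point. In an assay on isolated protein for inhibition of Trypsin (Homo sapiens) (a higher number here means a weaker inhibitor, a lower number a stronger inhibitor), compound 3 gives only a limit, > 5000 nM. Compound 1 `CCOc1cc([C@@H](Nc2ccc3cnccc3c2)C(=O)NS(=O)(=O)c2ccccc2)ccc1OC(C)C` in this assay also gives a limit, > 5000 nM. Compound 2 `CCOc1cc(C(Nc2ccc3cnccc3c2)C(=O)NS(=O)(=O)c2ccccc2)ccc1OC(C)C` likewise gives a limit in this assay, > 5000 nM. Among the compounds with values here, the single step among them, a step that the two limits leave unreadable from compound 1 to compound 2, cannot be read because the limit of > 5000 nM in this assay, at which 3 of the 3 values shown sit, and because of the fact that one of compounds 1 and 2 is drawn with a defined configuration and the other without, at the place where they differ. Compound 4 `CCOc1cc(C(Nc2ccc3c(N)nccc3c2)C(=O)NS(=O)(=O)c2ccc(N)cc2)ccc1OC(C)C` differs from compound 3 by 4-aminophenyl in place of 3-aminophenyl on a sulfonyl sulfur. Within the data shown here, no measured step involves this change, so no direction or size can be drawn from the measurements. Compound 4 is therefore expected to show a step that the limit leaves unreadable from compound 3 to compound 4 that stays within the scatter. The estimate for compound 4 in this assay is 8000 nM, between 3000 nM and 30000 nM.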

Compound 4, inhibition constant: > 5000 nM
Compound 4: a limit, no number; the forecaster's own chance of this, stated with the estimate: 85%; the middle value lies beyond the limit too.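

The step from compound 3 to compound 4 cannot be read, because both compounds give only a limit: the limit of > 5000 nM in this assay, at which 4 of the 4 values shown sit.
From the compounds shown here alone, how strongly any of the four compounds acts in this assay stays open, as does any difference between 3-aminophenyl and 4-aminophenyl.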